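A few compounds are considered here, and "the series" means these few. Any claim that something is new, unique, unknown or untested is made for them only; others in the source may bear on it.

Measured to date in a functional assay on A375P cells (Homo sapiens) for antiproliferative activity, read by MTT assay, with a stated time of 48 h; a higher number here means a weaker inhibitor, a lower number a stronger inhibitor:
compound 1 `COc1cc(-c2nn(-c3ccc(NC(=O)Nc4cc(C(F)(F)F)cc(C(F)(F)F)c4)cc3)cc2-c2ccncc2)ccc1Cl`, 11800 nM
compound 2 `COc1cc(-c2nn(-c3ccc(NC(=O)c4cc(C(F)(F)F)cc(C(F)(F)F)c4)cc3)cc2-c2ccncc2)ccc1Cl`, reported only as a limit of > 20000 nM
compound 3 `O=C(Nc1ccc(-n2cc(-c3ccncc3)c(-c3ccc(Cl)c(O)c3)n2)cc1)Nc1cccc(Cl)c1Cl`, 16800 nM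

Compound 3 holds the higher of the two numbers; its nearest neighbour, compound 1, lies within the scatter, so no order between them is claimed. Compound 2 gives only a limit, (the limit of > 20000 nM in this assay, at which 1 of the 3 values shown sits). Compound 4 `O=C(Nc1ccc(-n2cc(-c3ccncc3)c(-c3ccc(Cl)c(O)c3)n2)cc1)c1cc(Cl)cc(Cl)c1` is not yet measured in this assay. It differs from compound 3 in one place: 3,5-dichlorophenyl in place of (2,3-dichlorophenyl)amino on a carbonyl carbon. Within the data shown here, no step between measured pairs is available. Compound 1 and compound 2 differ at the same carbonyl position, and there the amide reads as a limit where the urea gives a number. The step of a 1.5-fold higher number from compound 3 to compound 4 (0.17 log units; within the scatter) is therefore expected toward a weaker inhibitor. Compound 4 is estimated at 25000 nM, ranging from 10000 nM to 60000 nM, with a real chance that only a limit is reported.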

Compound 4, half-maximal inhibitory concentration: 6800 nM
Estimate against measurement, compound 4: 3.7-fold (0.57 log units) above; the whole stated range lies above it.
By their numbers in this assay, from the lowest: compounds 4, 1 and 3 (each within the scatter of the next, the first and the last beyond it). At a limit, above all of these: compound 2.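

At this carbonyl carbon, this assay records a 2.5-fold lower number from compound 3 to compound 4 (0.39 log units; beyond the scatter), so an amide can read stronger than a urea in this series. The weaker reading of the amide suggested by compound 2 therefore does not hold at this position in general. Compound 2 remains only a limit: the limit of > 20000 nM in this assay, at which 1 of the 4 values shown sits.

Going by these compounds, the step removes the amino nitrogen and changes the chlorine arrangement together, so the share of each stays open. Also open, on these data alone, is how a sulfonamide in place of the carbonyl would read on the core of compound 4.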